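Replacing 3-methyl-1,2,4-oxadiazol-5-yl with 5-methylfuran-2-yl

A few compounds are considered here, and "the series" means these few. Any claim that something is new, unique, unknown or untested is made for them only; others in the source may bear on it.

Compound 1 `Cc1ccsc1-c1ccccc1NCC1=NCCN1` gives 49 nM in a functional assay for activation of Alpha-1D adrenergic receptor (Homo sapiens); a lower number here means that less compound is needed, a higher number that more compound is needed for the effect.
Compound 2 `Cc1noc(-c2ccccc2NCC2=NCCN2)n1` gives < 5020 nM in this assay, which is only a limit of the assay and not a number.

Compound 2 thus has no fixed place among the numbers shown; it stands only at the limit of < 5020 nM in this assay, at which 1 of the 2 values shown sits. The change to compound 3 `Cc1ccc(-c2ccccc2NCC2=NCCN2)o1` is 5-methylfuran-2-yl in place of 3-methyl-1,2,4-oxadiazol-5-yl on an aromatic carbon. Among the measured compounds shown here, the single measured step, a step that the limit leaves unreadable from compound 1 to compound 2, has no readable size, so no measured step gives a scale for the new change. What remains is compound 1, which carries 3-methylthiophen-2-yl on that aromatic carbon. Because compound 1 gives 49 nM, compound 3 is expected to reach about 100 nM, within 20 nM to 800 nM. The expected step is then a step that the limit leaves unreadable from compound 2 to compound 3, though a limit at its start leaves the true size open.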

Compound 3, half-maximal effective concentration: < 2000 nM
Compound 3: only a limit was reported; the forecaster's own chance of this, stated with the estimate: 10%; the middle value lies beyond the limit too.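

In this assay compound 3 gives < 2000 nM, which is only a limit of the assay and not a number. Among the compounds shown here, compound 2, at < 5020 nM, also has only a limit, and no step linking compound 3 to compound 1 or compound 2 can be read. As far as these compounds go, how 5-methylfuran-2-yl truly compares with 3-methylthiophen-2-yl or 3-methyl-1,2,4-oxadiazol-5-yl remains open.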